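Agonist efficacy notes: bromo to 4-chlorobenzyl on compound 2

The compounds below may be only part of what the source reports. "The series", "measured", "known", "first", "only" and "open" are said of these compounds alone.

Measured so far in a functional assay on CHO cells for agonist activity at Free fatty acid receptor 2 (Homo sapiens), read by cAMP accumulation; a higher number here means a larger maximal response, a lower number a smaller maximal response:
compound 1 `CC(C)[C@H](C(=O)Nc1ncc(C(N)=O)s1)c1ccc(Cl)cc1` gives 59%
compound 2 `CC(C)(C)[C@H](C(=O)Nc1ncc(Br)s1)c1ccc(Cl)cc1` gives 95%

Among the measured compounds shown here, compound 2 stands highest of the two numbers in this assay; compound 1 is the only other measured compound, and its value lies lower by a margin that is beyond the usual scatter. For the measured compounds named here, the two compounds differ in more than one place, so no single step between them is counted, and the gap is read only as what the two values show.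

Compound 3 `CC(C)(C)[C@H](C(=O)Nc1ncc(Cc2ccc(Cl)cc2)s1)c1ccc(Cl)cc1` is not yet measured. It differs from compound 2 in one place: 4-chlorobenzyl in place of bromo on an aromatic carbon. The group that leaves is a single heavy atom; the group that enters brings a six-membered aromatic ring of carbon only, without donors or acceptors, at the same ring carbon of the five-membered aromatic ring with one nitrogen and one sulfur.

Going by the values given here, nothing among the measured compounds shows what such a change does here. The step of a number 7 percentage points lower from compound 2 to compound 3 (within the scatter) in this assay is expected to be small, if anything slightly downward, and within the scatter. Compound 3 is therefore estimated to give 88%, in the range 60% to 110%.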

Compound 3, largest response reached (reported as efficacy), in percent of the reference or control that the assay uses: 100%
Compound 3: the middle estimate sits 12 percentage points below what was measured; low and high end bracket the measured number.
By their numbers in this assay, from the lowest: compound 1; then compounds 2 and 3 (each within the scatter of the next).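

In this assay the exchange of bromo for 4-chlorobenzyl gives a number 5 percentage points higher from compound 2 to compound 3 (within the scatter) and so places the two compounds within the scatter of each other. The aromatic carbon next to the ring sulfur therefore carries either a single bromine or a group of 8 heavy atoms with a six-membered aromatic ring of carbon only, and a high maximal response is kept with both groups. No measured evidence accompanies this result that could explain it.

Open, going by these compounds, is whether this holds for groups that bring hydrogen-bonding atoms, such as an amine or a carboxylic acid in place of the chlorine on the benzyl ring, or for a longer chain in place of the single carbon that links that ring to the core. Also open, on these data alone, is whether the same exchange behaves alike on the core of compound 1 , which gives 59% but differs from compound 2 in more than one place, so that its gap cannot be assigned to any single group.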